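The source may hold more compounds than are shown below. What is called first, only, known or untested is meant among the compounds shown, and "the series" means these compounds.

Compound 1 `Clc1cccc2sc(Nc3nc4ccccc4s3)nc12` gives > 50000 nM in a functional assay on THP-1 cells (Homo sapiens) for cytotoxicity, read by MTT assay, with a stated time of 48 h (on this read-out lower numbers stand for stronger inhibition and higher numbers for weaker inhibition), which is a limit of the assay and not a number. This places compound 1 at the limit of > 50000 nM in this assay, at which 1 of the 3 values shown sits. In this assay compound 2 `S=C(Nc1ccccc1)Nc1nc2c(Cl)cccc2s1` gives 31800 nM and compound 3 `c1ccc2sc(Nc3nc4ccccc4s3)nc2c1` gives 28800 nM, two values within the scatter of each other.

Compound 4 `Fc1ccc2nc(Nc3nc4c(Cl)cccc4s3)sc2c1` differs from compound 1 by fluoro in place of hydrogen on an aromatic carbon, with fluoro in place of hydrogen on an aromatic carbon. Among the measured compounds shown here, only one measured step bears on this, and only indirectly: an at least 1.7-fold lower number from compound 1 to compound 3 (0.23 log units; that floor lies within the scatter). That step exchanges chloro for hydrogen rather than hydrogen for fluoro, and it rests on a limit, so it gives no measured size for the new change. No step beyond the scatter is therefore expected in this assay, and no direction can be assigned with confidence. The expected change is an at least 1.1-fold lower number from compound 1 to compound 4 (0.04 log units; that floor lies within the scatter). The estimate for compound 4 is 45000 nM, with an expected range from 12000 nM to 80000 nM.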

Compound 4, half-maximal inhibitory concentration: 36200 nM
Compound 4: the middle estimate sits 1.2-fold (0.09 log units) above what was measured; measured number inside the range.
By their numbers in this assay, from the lowest: compounds 3, 2 and 4 (each within the scatter of the next). At a limit, above all of these: compound 1.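

In this assay, among the compounds shown here, the step of an at least 1.3-fold lower number from compound 1 to compound 4 (0.14 log units; that floor lies within the scatter) gives the first direct reading for fluoro in place of hydrogen on this six-membered aromatic ring of carbon only, as the earlier step concerned chloro in another place. Compound 1 stands at a limit of the assay and not at a number, so this step has only a floor: the limit of > 50000 nM in this assay, at which 1 of the 4 values shown sits.

From the compounds shown here alone, compound 4 gives 36200 nM in this assay, a measured number rather than a limit, but the true size of the change remains unknown.

Going by these compounds, whether an amine, a methoxy group or a carboxylic acid at this position would move the number beyond the scatter remains open. Also open, on these data alone, is what fluoro in place of hydrogen would do on the core of compound 3, which has a measured number as its starting point.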